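A few compounds are considered here, and "the series" means these few. Any claim that something is new, unique, unknown or untested is made for them only; others in the source may bear on it.

Values measured in an ADME assay on MT4 cells (Homo sapiens) for cytotoxicity, read by MTT assay; a lower number here means that less compound is tolerated, a higher number that more compound is tolerated:
- Compound 1 `Cc1ccc(C(=O)N(C(=S)OCCN2C(=O)c3ccccc3C2=O)c2ccc(Cl)cc2)cc1`: > 100000 nM
- Compound 2 `O=C1c2ccccc2C(=O)N1CCOC(=S)N(C(=O)c1ccc(C(F)(F)F)cc1)c1ccc(Cl)cc1`: 10000 nM
- Compound 3 `O=C1c2ccccc2C(=O)N1CCOC(=S)N(C(=O)c1ccc(F)c(F)c1)c1ccc(Cl)cc1`: 52000 nM

Compound 1 gives > 100000 nM, which is a limit of the assay and not an exact number. Of the two exact numbers, compound 3 has the higher, at 52000 nM. The gap to its nearest neighbour is a 5.2-fold higher number from compound 2 to compound 3 (0.72 log units; beyond the scatter).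

Compound 4 `O=C1c2ccccc2C(=O)N1CCOC(=S)N(C(=O)c1ccc(Cl)c(Cl)c1)c1ccc(Cl)cc1` carries 3,4-dichlorophenyl in place of 3,4-difluorophenyl on a carbonyl carbon. Changes on this same ring have already moved the numbers in this assay: there is an at least 10-fold lower number from compound 1 to compound 2 (1.00 log units; beyond the scatter), while an at least 1.9-fold lower number from compound 1 to compound 3 (0.28 log units; that floor lies within the scatter) says little. Within the data shown here, no measured step makes this exact swap, so the expectation rests on analogy. Compound 4 is placed between compound 2, at 10000 nM, and compound 3, at 52000 nM. A modest fall is expected, namely a 2.4-fold lower number from compound 3 to compound 4 (0.37 log units; beyond the scatter). For compound 4 the estimated value is 22000 nM, with an expected range from 7000 nM to 60000 nM.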

Compound 4, half-maximal cytotoxic concentration: 35000 nM
The estimate for compound 4 lay 1.6-fold (0.20 log units) below the measured number, within the range that was stated.
By their numbers in this assay, from the lowest: compound 2; then compounds 4 and 3 (each within the scatter of the next). At a limit, above all of these: compound 1.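

In this assay, 3,4-dichlorophenyl and 3,4-difluorophenyl on this carbonyl carbon cannot be told apart, with a 1.5-fold lower number from compound 3 to compound 4 (0.17 log units; within the scatter). The 4-(trifluoromethyl)phenyl group still stands apart from the new group, with a 3.5-fold higher number from compound 2 to compound 4 (0.54 log units; beyond the scatter), so among the exact numbers, the low reading of compound 2 now differs from two other rings rather than one. Set against 4-methylphenyl, there is an at least 2.8-fold lower number from compound 1 to compound 4 (0.45 log units; beyond the scatter), a floor that clears the scatter, unlike the one for 3,4-difluorophenyl, though its true size stays unknown with compound 1 at a limit: the limit of > 100000 nM in this assay, at which 1 of the 4 values shown sits.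

Open, from the compounds shown here alone, is whether a phenyl ring carrying a methoxy group would read like the two dihalogenated rings or like compound 2. Also open, going by these compounds, is how a ring bearing an amine would behave at this carbonyl carbon.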